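The compounds below may be only part of what the source reports. "The series", "measured", "known", "first", "only" and "open" are said of these compounds alone.

In an assay on THP-1 cells for displacement of a labelled ligand from C-C chemokine receptor type 1 (Homo sapiens) (a lower number here means a stronger inhibitor, a higher number a weaker inhibitor), compound 1 `Cc1ccccc1C(=O)N[C@@H](C(=O)N1CCC(c2ccc(Cl)cc2)CC1)C(C)C` gives 32 nM, compound 2 `CC(C)[C@@H](NC(=O)c1ccc(F)cc1)C(=O)N1CCC(c2ccc(Cl)cc2)CC1` gives 118 nM and compound 3 `Cc1ccc(CCC(=O)N[C@@H](C(=O)N2CCC(c3ccc(Cl)cc3)CC2)C(C)C)cc1` gives 105 nM. Compound 3 stands second highest of the three numbers: the nearest of the others shows a 1.1-fold lower number from compound 2 to compound 3 (0.05 log units; within the scatter), within the scatter, and the furthest shows a 3.3-fold higher number from compound 1 to compound 3 (0.52 log units; beyond the scatter), beyond it. Compound 4 `Cc1cccc(CCC(=O)N[C@@H](C(=O)N2CCC(c3ccc(Cl)cc3)CC2)C(C)C)c1` differs from compound 3 by 3-methylphenyl in place of 4-methylphenyl on a saturated chain carbon, two bonds along the chain from a carbonyl carbon. Among the compounds with values here, none of the measured steps keeps the same atoms and rejoins them differently: a 3.7-fold higher number from compound 1 to compound 2 (0.57 log units; beyond the scatter) and a 3.3-fold higher number from compound 1 to compound 3 (0.52 log units; beyond the scatter) each swap the whole acyl group and are modest, while a 1.1-fold lower number from compound 2 to compound 3 (0.05 log units; within the scatter) lies within the scatter. The step in this assay is therefore expected to stay within the scatter, with no set direction. Compound 4 is estimated at 105 nM, between 40 nM and 280 nM, a step of no change at the digits printed from compound 3 to compound 4 (within the scatter).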

Compound 4, half-maximal inhibitory concentration: 22 nM
Compound 4: the middle estimate sits 4.8-fold (0.68 log units) above what was measured; the measured number lies below the stated range.
By their numbers in this assay, from the lowest: compounds 4 and 1 (each within the scatter of the next); then compounds 3 and 2 (each within the scatter of the next).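

In this assay, within the data shown here, going from 4-methylphenyl to 3-methylphenyl gives a 4.8-fold lower number from compound 3 to compound 4 (0.68 log units; beyond the scatter) on the same atoms, so this position responds to rejoining alone, which no earlier step showed. The 2-(3-methylphenyl)ethyl group gives a 5.4-fold lower number from compound 2 to compound 4 (0.73 log units; beyond the scatter) when it replaces 4-fluorophenyl, while replacing 2-methylphenyl gives a 1.5-fold lower number from compound 1 to compound 4 (0.16 log units; within the scatter), so the chain group need not lose out to the directly attached aryl group, as compound 3 alone suggested. No measurement at hand accounts for this.

Still open, on these data alone, is how 2-(2-methylphenyl)ethyl compares on the same chain. Also open, as far as these compounds go, is whether 2-(3-chlorophenyl)ethyl, 2-(3-methoxyphenyl)ethyl or the longer 3-(3-methylphenyl)propyl keeps the number this low.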